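Opening a glutamine-type side chain on the chlorinated core

A few compounds are considered here, and "the series" means these few. Any claim that something is new, unique, unknown or untested is made for them only; others in the source may bear on it.

Measured so far:
Compound 1 `N=C(N)NCCC[C@H](NC(=O)CN(c1ncnc2c1ncn2C1CCCCO1)C1CC1)C(=O)OCc1ccccc1`: 19.6%
Compound 2 `CC[C@H](C)[C@H](NC(=O)CN(c1nc(Cl)nc2[nH]cnc12)C1CC1)C(=O)OCc1ccccc1`: 6.9%
Compound 3 `C[C@H](NC(=O)CN(c1ncnc2c1ncn2C1CCCCO1)C1CC1)C(=O)OCc1ccccc1`: 6.01%

All three were tested in a functional assay on the whole organism (Tail, strain ICR) with Mus musculus as the target, in the tail flick test, with a stated time of 150 min, at a dose of 25 umol/kg by the oral route; on this read-out higher numbers stand for a stronger effect at the one dose given and lower numbers for a weaker effect. Compound 2 stands second highest of the three numbers; compound 3 lies within the scatter of it, while compound 1 lies beyond the scatter above it. Going by the values given here, the only single-place step among the measured compounds is a number 13.6 percentage points lower from compound 1 to compound 3 (beyond the scatter), and there a hydrogen in place of a larger side chain, on the shared peptide-like carbon, lowered the read-out.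

Compound 4 `NC(=O)CC[C@H](NC(=O)CN(c1nc(Cl)nc2[nH]cnc12)C1CC1)C(=O)OCc1ccccc1` has not yet been measured. It differs from compound 2 by 2-carbamoylethyl in place of sec-butyl on a saturated chain carbon bound to an amide-type nitrogen and a carbonyl carbon. Among the compounds with values here, no measured step covers this exact exchange, and compound 2 carries a different core from compounds 1 and 3, so the bearing of the step from compound 1 to compound 3 is loose: it shows only that a side chain with donors and acceptors outperformed a bare hydrogen there. Compound 4 is therefore expected to rise slightly, by a number 3.1 percentage points higher from compound 2 to compound 4 (within the scatter), a change within the scatter. The estimate for compound 4 in this assay is 10%, with a range from 3% to 20%.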

Compound 4, a percentage reported as activity, at one dose (the size of the read-out at that dose, not a potency): 31.1%
Compound 4: the middle estimate sits 21.1 percentage points below what was measured, and the stated range ends below it.
By their numbers in this assay, from the lowest: compounds 3 and 2 (each within the scatter of the next); then compound 1; then compound 4.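

In this assay, the exchange of sec-butyl for 2-carbamoylethyl on the core of compound 2 gives a number 24.2 percentage points higher from compound 2 to compound 4 (beyond the scatter). The earlier step showed only a side chain set against a bare hydrogen, on another core, whereas this one shows that the read-out at this saturated chain carbon also depends on which side chain is present. The entering group has the hydrogen-bond donor and acceptor that sec-butyl lacks, but nothing shown here gives a measured reason for the rise.

The compounds shown leave open whether a carboxylic acid, an amine or a longer chain bearing the same amide, in place of 2-carbamoylethyl, would keep this read-out. Also open, from the compounds shown here alone, is whether the same exchange would give a similar step on the core of compound 3.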